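Series notes: terminal aryl variation ahead of compound 4

This account rests on a few compounds, and the source may have more. Where it says the series, first, only, none or still open, it means among the compounds named here.

Three members share one core: compound 1 is `COC(=O)/C=C/c1cccc(N(Cc2ccc(/C=C/c3cccc(F)c3)cc2)C(=O)C(C)C)c1`, compound 2 is `COC(=O)/C=C/c1cccc(N(Cc2ccc(/C=C/c3ccccn3)cc2)C(=O)C(C)C)c1` and compound 3 is `COC(=O)/C=C/c1cccc(N(Cc2ccc(-c3ccc(OC)cc3)cc2)C(=O)C(C)C)c1`. In an assay on isolated protein with Bile acid receptor (Homo sapiens) as the target (a higher number here means that more compound is needed for the effect, a lower number that less compound is needed), compound 1 gives 71 nM, compound 2 gives 310 nM and compound 3 gives 97 nM. Compound 3 thus holds the second highest of the three numbers; its nearest neighbour is compound 1, within the scatter, and the wider gap is a 3.2-fold lower number from compound 2 to compound 3 (0.50 log units; beyond the scatter). The remaining steps are a 4.4-fold higher number from compound 1 to compound 2 (0.64 log units; beyond the scatter) and a 1.4-fold higher number from compound 1 to compound 3 (0.14 log units; within the scatter).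

Compound 4 is `COC(=O)/C=C/c1cccc(N(Cc2ccc(-c3c(OC)cccc3OC)cc2)C(=O)C(C)C)c1`. It differs from compound 3 by 2,6-dimethoxyphenyl in place of 4-methoxyphenyl on an aromatic carbon. Within the data shown here, no measured step alters the substitution pattern of an aryl group that sits directly on the aromatic carbon para to the large group; the steps seen exchange entire substituents. Because a 1.4-fold higher number from compound 1 to compound 3 (0.14 log units; within the scatter) lay within the scatter when an aryl group first took that position, only a small step in this assay is expected for compound 4, with no firm direction: a 1.4-fold higher number from compound 3 to compound 4 (0.16 log units; within the scatter). The estimate for compound 4 in this assay is 140 nM, with a range from 50 nM to 400 nM.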

Compound 4, half-maximal effective concentration: 95 nM
Beside the measured number, compound 4's estimate is 1.5-fold (0.17 log units) above it; the measured number falls inside the stated range.
By their numbers in this assay, from the lowest: compounds 1, 4 and 3 (each within the scatter of the next); then compound 2.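

Working from 4-methoxyphenyl to 2,6-dimethoxyphenyl on an aromatic carbon para to a large group, this assay shows a 1.0-fold lower number from compound 3 to compound 4 (0.01 log units; within the scatter) as the outcome. Among these compounds, this is the first change of substitution pattern on a directly attached aryl group, and it stays within the scatter despite the added methoxy group. Compound 4 also reads as compound 3 does against the ethenyl-linked members, with a 3.3-fold lower number from compound 2 to compound 4 (0.51 log units; beyond the scatter) as the wider gap and a 1.3-fold higher number from compound 1 to compound 4 (0.13 log units; within the scatter) as the narrow one, so compound 2 alone stands apart among the four.

No supporting data bear on why this change leaves the number within the scatter. Still open, going by these compounds, is how this position responds to a directly attached aryl group carrying an amine or a carboxylic acid rather than methoxy groups.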